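A few compounds are considered here, and "the series" means these few. Any claim that something is new, unique, unknown or untested is made for them only; others in the source may bear on it.

Two members of the series carry a silyl ether on the primary alcohol: compound 1 `C=C1CC[C@@H]2[C@](C)(CO[Si](C(C)C)(C(C)C)C(C)C)[C@H](O)CC[C@@]2(C)[C@@H]1C/C=C1/C(=O)OC[C@H]1O` and compound 2 `C=C1CC[C@@H]2[C@](C)(CO[Si](C)(C)C(C)(C)C)[C@H](O)CC[C@@]2(C)[C@@H]1C/C=C1/C(=O)OC[C@H]1OC(C)=O`. In a functional assay on ASK cells (Rattus norvegicus) for cytotoxicity, read by sulforhodamine B assay (on this read-out lower numbers stand for an effect already at smaller amounts and higher numbers for an effect only at larger amounts of compound), compound 2 gives 3.41 uM, the higher of the two numbers recorded, while compound 1 gives 2.85 uM, which sits within the scatter of compound 2. Compound 3 `C=C1CC[C@@H]2[C@](C)(COC(C)=O)[C@H](O)CC[C@@]2(C)[C@@H]1C/C=C1/C(=O)OC[C@H]1OC(C)=O` has not been measured. It differs from compound 2 by a group of 3 heavy atoms (2 carbon, 1 oxygen; no ring) in place of a group of 7 heavy atoms (6 carbon, 1 silicon; no ring), on an oxygen on a saturated carbon. Among the compounds with values here, no step between measured compounds covers this change, so nothing beyond the scatter is expected; compound 3 is estimated at 3.5 uM (range 1.5 uM to 8 uM), an expected step of a 1.0-fold higher number from compound 2 to compound 3 (0.01 log units; within the scatter).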

Compound 3, concentration for half-maximal effect: 16.3 uM
Beside the measured number, compound 3's estimate is 4.7-fold (0.67 log units) below it; the whole stated range lies below it.
By their numbers in this assay, from the lowest: compounds 1 and 2 (each within the scatter of the next); then compound 3.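

In this assay, within the data shown here, acetyl in place of the silyl group, on an oxygen on a saturated carbon, gives a 4.8-fold higher number from compound 2 to compound 3 (0.68 log units; beyond the scatter), the first step that lies beyond the scatter. This position is therefore not indifferent to its substituent, and here the silyl group carries the lower number. Nothing at hand accounts for this step. Still open, on these data alone, is whether the trend follows group size, as a longer acyl chain or a benzyl group on this oxygen could show. The free alcohol also remains to be placed against both groups.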